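Biaryl series: pyridin-4-yl in place of carboxy

This account rests on a few compounds, and the source may have more. Where it says the series, first, only, none or still open, it means among the compounds named here.

Measured so far in an assay on isolated protein for inhibition of methionine--tRNA ligase, cytoplasmic (Homo sapiens); a higher number here means a weaker inhibitor, a lower number a stronger inhibitor:
compound 1 `NC(=O)c1cc(-c2ccc(-c3ccc(Cl)cc3Cl)cc2)n(-c2ccccn2)n1` gives > 100000 nM, a limit of the assay.
compound 2 `O=C(O)c1cc(-c2ccc(-c3ccc(Cl)cc3Cl)cc2)n(Cc2cccnc2)n1` gives > 100000 nM, a limit of the assay.
compound 3 `O=C(O)Cn1nc(C(=O)O)cc1-c1ccc(-c2ccc(Cl)cc2Cl)cc1` gives 100000 nM.

Going by the values given here, compound 3 holds the only number in this set; the other two entries are limits. Among the compounds with values here, the one measured step, a number no higher from compound 2 to compound 3 (the limit leaves the size open), cannot be sized because compound 2 sits at the limit of > 100000 nM in this assay, at which 2 of the 3 values shown sit.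

Compound 4 `O=C(O)c1cc(-c2ccc(-c3ccc(Cl)cc3Cl)cc2)n(Cc2ccncc2)n1` differs from compound 3 by pyridin-4-yl in place of carboxy on a saturated chain carbon bound to an aromatic nitrogen. This runs the measured step backwards in kind, with pyridin-4-yl rather than pyridin-3-yl entering, so compound 4 is expected to remain close to the assay limit in this assay. Compound 4 is estimated at 120000 nM, within 50000 nM to 300000 nM. The step this estimate means, a 1.2-fold higher number from compound 3 to compound 4 (0.08 log units; within the scatter), is expected to be no larger than the scatter, if a number is returned at all.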

Compound 4, half-maximal inhibitory concentration: 26200 nM
Compound 4: middle estimate off by 4.6-fold (0.66 log units), on the high side; measured number below the stated range.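

Going by these compounds alone, on the saturated chain carbon bound to an aromatic nitrogen, the group now makes a readable difference in this assay: pyridin-4-yl in place of carboxy gives a 3.8-fold lower number from compound 3 to compound 4 (0.58 log units; beyond the scatter) as the first step with a readable size. Pyridin-4-yl in place of pyridin-3-yl gives an at least 3.8-fold lower number from compound 2 to compound 4 (0.58 log units; beyond the scatter) and shows that the two pyridinyl groups are not interchangeable here. On these data alone, the size of that second step stays open on one side: the limit of > 100000 nM in this assay, at which 2 of the 4 values shown sit.

As far as these compounds go, whether a longer chain carrying the pyridin-4-yl ring, or an amine at this place, would lower the number further remains open.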